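Adding a nitro group to compound 1

The source may report more compounds than this note shows. Statements on the series, on what has been measured and on what is new or still open speak of the compounds shown alone.

In a functional assay on K562/A02 cells (Homo sapiens) for antiproliferative activity, read by MTT assay (on this read-out lower numbers stand for stronger inhibition and higher numbers for weaker inhibition), compound 1 `O=C(CCCCCNC(=S)NN=C(c1ccccc1)c1ccccc1)NO` gives 3640 nM. Compound 3 `C/C(=N\NC(=S)NCCCCCC(=O)NO)c1cccc(C)c1` gives 3570 nM, within the scatter of compound 1, while compound 2 `C/C(=N\NC(=S)NCCCCCC(=O)NO)c1cccc(C(F)(F)F)c1` gives 890 nM, a lower number beyond the scatter.

Compound 4 `O=C(CCCCCNC(=S)N/N=C(\c1ccccc1)c1ccc([N+](=O)[O-])cc1)NO` carries one change from compound 1: nitro in place of hydrogen on an aromatic carbon, para to a large group (nitro in place of hydrogen on an aromatic carbon). Within the data shown here, no measured step involves nitro. Among the measured compounds shown here, the only step available is a 4.0-fold higher number from compound 2 to compound 3 (0.60 log units; beyond the scatter), with methyl in place of trifluoromethyl on an aromatic carbon. This step is modest, and it comes from a pair that also differs from compound 1 elsewhere in the core. For the measured compounds named here, it therefore offers only weak guidance: a shift towards a lower number in this assay is expected, no larger than that step and possibly lost in the scatter. The estimated step is a 1.8-fold lower number from compound 1 to compound 4 (0.26 log units; within the scatter). Compound 4 is estimated at 2000 nM, with an expected range of 700 nM to 5000 nM.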

Compound 4, half-maximal inhibitory concentration: 4530 nM
For compound 4 the middle estimate is 2.3-fold (0.36 log units) below the measured one; the range from low to high includes it.
By their numbers in this assay, from the lowest: compound 2; then compounds 3, 1 and 4 (each within the scatter of the next).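

In this assay, nitro in place of hydrogen on an aromatic carbon, para to a large group, gives a 1.2-fold higher number from compound 1 to compound 4 (0.09 log units; within the scatter). Among these compounds, on the core of compound 1, then, this position takes a group of 3 heavy atoms with a step that stays within the scatter, the first measured reading for this position and for nitro; the earlier step, a 4.0-fold higher number from compound 2 to compound 3 (0.60 log units; beyond the scatter), belongs to a different core and exchanges other groups. Nothing measured here bears on why the nitro step is this small.

From the compounds shown here alone, whether an amine or a methoxy group at this same position would also stay within the scatter remains open. So does whether trifluoromethyl at this position on the core of compound 1 would give a lower number.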